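This account rests on a few compounds, and the source may have more. Where it says the series, first, only, none or still open, it means among the compounds named here.

Measured compounds:
- compound 2 `N[C@H]1CC[C@H](Nc2c(C(=O)NCc3ccc(Cl)cc3)nc(Br)c3cccnc23)CC1`: 1000 nM
- compound 1 `CN(C)c1ccc(CNC(=O)c2nc(Br)c3cccnc3c2N[C@H]2CC[C@H](N)CC2)cc1`: 5300 nM

In a functional assay on HEY cells (Homo sapiens) for cytotoxicity, read by MTT assay, with a stated time of 72 h (a higher number here means a weaker inhibitor, a lower number a stronger inhibitor), compound 2 gives the lower of the two numbers; compound 1 gives the higher, a 5.3-fold lower number from compound 1 to compound 2 (0.72 log units; beyond the scatter). Compound 3 `N[C@H]1CC[C@H](Nc2c(C(=O)Nc3ccccc3)nc(Br)c3cccnc23)CC1` differs from compound 2 at the amide-type nitrogen: phenyl in place of 4-chlorobenzyl on an amide-type nitrogen. Among the compounds with values here, no measured step touches this position; the only known step concerns the aromatic substituent on the benzyl ring, so it does not bear on the change here. With no guidance, the estimate for compound 3 in this assay is a somewhat higher number, a 2.0-fold higher number from compound 2 to compound 3 (0.30 log units; within the scatter), giving an expected value of 2000 nM within 500 nM to 8000 nM.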

Compound 3, half-maximal inhibitory concentration: 1000 nM
For compound 3 the middle estimate is 2.0-fold (0.30 log units) above the measured one; the measured number falls inside the stated range.
By their numbers in this assay, from the lowest: compounds 2 and 3 (each within the scatter of the next); then compound 1.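

In this assay, phenyl in place of 4-chlorobenzyl on the amide-type nitrogen gives no change at the digits printed from compound 2 to compound 3 (within the scatter) and so the 4-chlorobenzyl group is not needed to hold this level of cytotoxicity. Phenyl in place of 4-(dimethylamino)benzyl gives a 5.3-fold lower number from compound 1 to compound 3 (0.72 log units; beyond the scatter) and so the phenyl amide sits with the 4-chlorobenzyl amide, apart from the 4-(dimethylamino)benzyl amide. Nothing available explains either step. Still open, from the compounds shown here alone, is how an unsubstituted benzyl group compares on this nitrogen. Also open, going by these compounds, is whether a 4-chlorophenyl or cyclohexyl group there changes the number.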